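Swapping the bicyclic ring on the urea nitrogen

The source may report more compounds than this note shows. Statements on the series, on what has been measured and on what is new or still open speak of the compounds shown alone.

For the measured compounds named here, compound 2 `O=C(Nc1noc2ccncc12)N1CCN(Cc2cccc(Oc3ccc(Cl)cc3)c2)CC1` gives 2200 nM in an assay on isolated protein for inhibition of Fatty-acid amide hydrolase 1 (Rattus norvegicus), with a stated time of 60 min (on this read-out lower numbers stand for stronger inhibition and higher numbers for weaker inhibition), the lower of the two numbers measured so far. Going by the values given here, its only neighbour, compound 1 `O=C(Nc1cccc2cn[nH]c12)N1CCN(Cc2cccc(Oc3ccc(Cl)cc3)c2)CC1`, gives 6000 nM in this assay, so the step of a 2.7-fold lower number from compound 1 to compound 2 (0.44 log units; beyond the scatter) is the one comparison available. Compound 3 `O=C(Nc1cccc2nccn12)N1CCN(Cc2cccc(Oc3ccc(Cl)cc3)c2)CC1` has not yet been measured. It differs from compound 2 by a group of 9 heavy atoms (7 carbon, 2 nitrogen; one five-membered aromatic ring with 2 hetero atoms, one six-membered aromatic ring with 1 hetero atom) in place of a group of 9 heavy atoms (6 carbon, 2 nitrogen, 1 oxygen; one five-membered aromatic ring with 2 hetero atoms, one six-membered aromatic ring with 1 hetero atom), on an amide-type nitrogen. The measured step shows that changing this bicyclic group can move the number by a modest amount, but it involved a different pair of groups, so it only loosely bears on the present change. Among the compounds with values here, with no closer precedent, the expectation for compound 3 is a small step of a 1.4-fold higher number from compound 2 to compound 3 (0.13 log units; within the scatter) that may well fall within the scatter, possibly toward a somewhat higher number. The estimate for compound 3 in this assay is therefore 3000 nM, with a range from 1000 nM to 9000 nM.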

Compound 3, half-maximal inhibitory concentration: 5.7 nM
Estimate against measurement, compound 3: 530-fold (2.72 log units) above, and the stated range ends above it.
By their numbers in this assay, from the lowest: compound 3; then compound 2; then compound 1.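

In this assay, the choice of bicyclic group on this amide-type nitrogen turns out to matter far more than the earlier comparison showed: the change from the oxygen-containing group to the all-carbon-and-nitrogen group gives a 390-fold lower number from compound 2 to compound 3 (2.59 log units; beyond the scatter), against only a 2.7-fold lower number from compound 1 to compound 2 (0.44 log units; beyond the scatter) before. The same entering group, set against the group in compound 1, gives a 1100-fold lower number from compound 1 to compound 3 (3.02 log units; beyond the scatter), so it stands far ahead of both other groups shown. The groups leaving and entering in the step from compound 2 have the same heavy-atom count and the same ring types, so these alone do not set the number.

No measurement is available to explain this result. Also open, as far as these compounds go, is whether adding a methyl group or an amine to the entering bicyclic group would keep so low a number.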